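The source may report more compounds than this note shows. Statements on the series, on what has been measured and on what is new or still open speak of the compounds shown alone.

Measured so far in a functional assay on NCI-H460 cells (Homo sapiens) for antiproliferative activity, read by XTT assay, with a stated time of 72 h; a higher number here means a weaker inhibitor, a lower number a stronger inhibitor:
compound 1, `COc1ccc(-c2cc3ccccc3nc2/C=C/C(=O)c2ccccc2)cc1`: 6670 nM
compound 2, `COc1ccc(C(=O)/C=C/c2nc3ccccc3cc2-c2ccc(OC)cc2)cc1`: a limit only

Compound 2 stands at a limit of this assay: in this assay compound 2 gives > 10000 nM, a limit and not a number (the limit of > 10000 nM in this assay, at which 1 of the 2 values shown sits). Within the data shown here, the single measured step, an at least 1.4-fold higher number from compound 1 to compound 2 (0.17 log units; that floor lies within the scatter), is therefore known only as a floor, and that floor lies within the scatter.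

Compound 3, `COc1ccc(-c2cc3ccccc3nc2/C=C/C(=O)c2cccs2)cc1`, differs from compound 2 by thiophen-2-yl in place of 4-methoxyphenyl on a carbonyl carbon. Among the measured compounds shown here, the methoxy-bearing ring on the carbonyl carbon is thus replaced outright, so the step from compound 1 to compound 2 bears on the change only loosely; no measured step in this assay covers an aryl-to-thiophenyl swap on the carbonyl carbon. In this assay the step from compound 2 to compound 3 is expected to be small, an at least 1.2-fold lower number from compound 2 to compound 3 (0.09 log units; that floor lies within the scatter), or none beyond the scatter. Compound 3 is estimated at 8000 nM, within a range from 3000 nM to 20000 nM, with a real chance that this assay again reports only a limit.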

Compound 3, half-maximal inhibitory concentration: 5440 nM
Estimate against measurement, compound 3: 1.5-fold (0.17 log units) above; the range from low to high includes it.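

In this assay, thiophen-2-yl in place of phenyl on the carbonyl carbon gives a 1.2-fold lower number from compound 1 to compound 3 (0.09 log units; within the scatter), so these two aromatic rings cannot be told apart at this position. Thiophen-2-yl in place of 4-methoxyphenyl gives an at least 1.8-fold lower number from compound 2 to compound 3 (0.26 log units; that floor lies within the scatter). Compound 2 stands at a limit and not at a number, so this step is known only as a floor, and any cost of the methoxy group stays unsized: the limit of > 10000 nM in this assay, at which 1 of the 3 values shown sits.

Open, on these data alone, is whether a non-aromatic group on the carbonyl carbon, such as a short alkyl chain or a cyclic amine, would move the number beyond the scatter. Also open, as far as these compounds go, is what a carboxylic acid or an amine would do in place of the methoxy group on the aryl ring of the shared core.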